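Compound 2 to compound 3: a new amide end

The source may report more compounds than this note shows. Statements on the series, on what has been measured and on what is new or still open speak of the compounds shown alone.

Compound 1 `COc1cccc(F)c1CNC(=O)c1[nH]c2ccc(Cl)cc2c1S(=O)(=O)c1cc(C)cc(C)c1` gives > 49900 nM as a limit
Compound 2 `Cc1cc(C)cc(S(=O)(=O)c2c(C(=O)NCC(=O)NC(C)c3ccccc3F)[nH]c3ccc(Cl)cc23)c1` gives 23000 nM as a number

Going by the values given here, in an ADME assay on MT4 cells (Homo sapiens) for cytotoxicity, read by MTT assay (a lower number here means that less compound is tolerated, a higher number that more compound is tolerated), compound 2 holds the only true number (23000 nM). The value of compound 1 is a limit. Among the compounds with values here, the one measured step is an at least 2.1-fold lower number from compound 1 to compound 2 (0.33 log units; beyond the scatter), and it brought in the 1-(2-fluorophenyl)ethyl group. Compound 3 `Cc1cc(C)cc(S(=O)(=O)c2c(C(=O)NCC(=O)NCc3ccncn3)[nH]c3ccc(Cl)cc23)c1` loses that group: (pyrimidin-4-yl)methyl in place of 1-(2-fluorophenyl)ethyl on an amide-type nitrogen. Within the data shown here, with only that step to go on, a modest rise in this assay is expected. For compound 3 the expected step is a 2.1-fold higher number from compound 2 to compound 3 (0.32 log units; beyond the scatter) and no larger claim is made. Compound 3 is estimated at 48000 nM, within 20000 nM to 90000 nM, and it may yield only a limit.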

Compound 3, half-maximal cytotoxic concentration: > 48800 nM
Compound 3 ended at the assay's limit (the forecaster's own chance of this, stated with the estimate: 55%); middle value at least 1.0-fold (0.00 log units) away from the limit.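

In this assay, (pyrimidin-4-yl)methyl in place of 1-(2-fluorophenyl)ethyl on an amide-type nitrogen gives an at least 2.1-fold higher number from compound 2 to compound 3 (0.32 log units; beyond the scatter), which shows that the number can also rise with a change at this end of the amide. Going by these compounds, compound 3 gives a limit, not a number, and the full size of the rise stays unknown: the limit of > 48800 nM in this assay, at which 1 of the 3 values shown sits. Compound 1 and compound 3 both give limits, and the step between them cannot be read.

On these data alone, whether the rise goes with the ring nitrogens or with the loss of the fluorine stays open. A plain benzyl or a (pyridin-4-yl)methyl group on this nitrogen would separate the two.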